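The source may hold more compounds than are shown below. What is called first, only, known or untested is meant among the compounds shown, and "the series" means these compounds.

Compound 1 `CNc1nc(Nc2ccc(C)c(N)c2)ncc1C(=O)Nc1cc(NC(=O)c2cccc(OC)c2)ccc1C` and compound 2 `CNc1nc(Nc2ccc(C)c(N)c2)ncc1C(=O)Nc1cc(NC(=O)c2ccc(OC)cc2)ccc1C` share one core and differ only in where a methoxy sits on the carbonyl-bearing ring. In a functional assay on K562 cells (Homo sapiens) for antiproliferative activity, read by CellTiter-Glo and CCK-8 assay, with a stated time of 72 h (on this read-out lower numbers stand for stronger inhibition of growth and higher numbers for weaker inhibition of growth), compound 1 gives 330 nM, and compound 2 gives 610 nM. The step of a 1.8-fold higher number from compound 1 to compound 2 (0.27 log units; within the scatter) leaves the two inseparable, so compound 2 holds the upper of two numbers that the scatter covers. Compound 3 `CNc1nc(Nc2ccc(C)c(N)c2)ncc1C(=O)Nc1cc(NC(=O)c2ccc(OC)c(OC)c2)ccc1C` differs from compound 2 by methoxy in place of hydrogen on an aromatic carbon. Going by the values given here, no measured step adds a group, and the single step moved one without effect, so no change beyond the scatter is expected, a 1.2-fold lower number from compound 2 to compound 3 (0.09 log units; within the scatter). Compound 3 is estimated at 500 nM, between 200 nM and 1500 nM.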

Compound 3, concentration for 50% growth inhibition: 380 nM
Compound 3: middle estimate off by 1.3-fold (0.12 log units), on the high side; measured number inside the range.
By their numbers in this assay, from the lowest: compounds 1, 3 and 2 (each within the scatter of the next).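

Going from 4-methoxyphenyl to 3,4-dimethoxyphenyl puts a second methoxy on the ring, and in this assay this gives a 1.6-fold lower number from compound 2 to compound 3 (0.21 log units; within the scatter). Counted from the other single-methoxy compound, the result is a 1.2-fold higher number from compound 1 to compound 3 (0.06 log units; within the scatter), so this ring accepts two methoxy groups with no change beyond the scatter from either one-methoxy compound. No measured evidence here offers an explanation for this result.

From the compounds shown here alone, what remains open is whether a different group on this ring, such as an amine or a carboxylic acid, would shift growth inhibition beyond the scatter.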